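Weak Antiproliferative Benzyladenosines and an Untested Dihydroxy Analogue

A few compounds are considered here, and "the series" means these few. Any claim that something is new, unique, unknown or untested is made for them only; others in the source may bear on it.

Measured compounds:
compound 1, `OC[C@H]1O[C@@H](n2cnc3c(NCc4ccccc4Cl)ncnc32)[C@H](O)[C@@H]1O` — in a functional assay on G-361 cells (Homo sapiens) for antiproliferative activity, with a stated time of 72 h (on this read-out lower numbers stand for stronger inhibition and higher numbers for weaker inhibition), compound 1 gives "not determined" (no result reported)
compound 2, `COc1ccc(CNc2ncnc3c2ncn3[C@@H]2O[C@H](CO)[C@@H](O)[C@H]2O)c(OC)c1` — in this assay compound 2 gives "not determined" (no result reported)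
compound 3, `COc1cccc(CNc2ncnc3c2ncn3[C@@H]2O[C@H](CO)[C@@H](O)[C@H]2O)c1O` — in this assay compound 3 gives 148000 nM

Compound 1 has no number of its own in this assay; of the three measured compounds only compound 3 carries a value, and that value is very weak. Compound 4, `OC[C@H]1O[C@@H](n2cnc3c(NCc4cc(O)cc(O)c4)ncnc32)[C@H](O)[C@@H]1O`, differs from compound 1 by 3,5-dihydroxyphenyl in place of 2-chlorophenyl on a saturated chain carbon bound to a nitrogen on an aromatic ring. Within the data shown here, no step between measured compounds is available, so the size and direction of the change from compound 1 to compound 4 in this assay cannot be taken from the data; a step within the scatter or of modest size in either direction is expected. Resting on compound 3 as the only anchor, compound 4 is expected to give about 100000 nM, estimated between 20000 nM and 500000 nM.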

Compound 4, half-maximal inhibitory concentration: > 166000 nM
Compound 4: only a limit was reported; the forecaster's own chance of this, stated with the estimate: 40%; at least 1.6-fold (0.22 log units) between middle value and limit.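

In this assay compound 4 reaches only a limit of the assay, > 166000 nM. Among these compounds, this gives the first reading for a second group at this position, on a saturated chain carbon bound to a nitrogen on an aromatic ring, and the step is an at least 1.1-fold higher number from compound 3 to compound 4 (0.04 log units; that floor lies within the scatter). Placing 3,5-dihydroxyphenyl in place of 2-hydroxy-3-methoxyphenyl therefore brings no sign of stronger inhibition.

Steps from compound 1 and compound 2 cannot be read, as neither has a number. On these data alone, how an amine or a carboxylic acid would read in place of 3,5-dihydroxyphenyl stays open.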